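Ring versus chain amines at the aromatic carbon

The compounds below may be only part of what the source reports. "The series", "measured", "known", "first", "only" and "open" are said of these compounds alone.

Measured compounds:
compound 1 `CN[C@@H]1CCN(c2cc3c(cc2F)c(=O)c(C(=O)O)cn3Cc2ccc(-c3ccccc3)cc2)C1`: 34800 nM
compound 2 `O=C(O)c1cn(Cc2ccc(-c3ccccc3)cc2)c2cc(N3CC4CNCC4C3)c(F)cc2c1=O`: 33300 nM
compound 3 `CNCCNc1cc2c(cc1F)c(=O)c(C(=O)O)cn2Cc1ccc(-c2ccccc2)cc1`: > 200000 nM

In an assay on isolated protein for inhibition of DNA topoisomerase 1 (Homo sapiens), with a stated time of 15 min (a higher number here means a weaker inhibitor, a lower number a stronger inhibitor), compound 1 gives 34800 nM and compound 2 gives 33300 nM, and these two sit within the scatter of each other (a 1.0-fold lower number from compound 1 to compound 2 (0.02 log units; within the scatter)). Compound 3 carries the open-chain amine and in this assay reaches only the limit > 200000 nM, which is a limit of the measurement and not a number (the limit of > 200000 nM in this assay, at which 1 of the 3 values shown sits). Among the compounds with values here, compound 3 is therefore the one compound here with a limit rather than a value, and both measured steps onto it point the same way: an at least 5.7-fold higher number from compound 1 to compound 3 (0.75 log units; beyond the scatter) and an at least 6.0-fold higher number from compound 2 to compound 3 (0.77 log units; beyond the scatter).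

Compound 4 `O=C(O)c1cn(Cc2ccc(-c3ccccc3)cc2)c2cc(NC[C@@H]3CCNC3)c(F)cc2c1=O` differs from compound 3 in one place: pyrrolidin-3-yl in place of (methylamino)methyl on a saturated chain carbon bound to a nitrogen on an aromatic ring. The change returns a five-membered ring to the side chain, which both measured steps connect with a lower number. For compound 4 the number in this assay is therefore expected to fall, by roughly an at least 1.6-fold lower number from compound 3 to compound 4 (0.22 log units; that floor lies within the scatter), though a limit remains possible since compound 3 itself gave only one. Compound 4 is estimated at 120000 nM, between 40000 nM and 300000 nM.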

Compound 4, half-maximal inhibitory concentration: 104000 nM
Estimate against measurement, compound 4: 1.2-fold (0.06 log units) above; the measured number falls inside the stated range.
By their numbers in this assay, from the lowest: compounds 2 and 1 (each within the scatter of the next); then compound 4. At a limit, above all of these: compound 3.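

Compound 3 remains at a limit of the assay and not a number: the limit of > 200000 nM in this assay, at which 1 of the 4 values shown sits.

Pyrrolidin-3-yl in place of (methylamino)methyl gives an at least 1.9-fold lower number from compound 3 to compound 4 (0.28 log units; that floor lies within the scatter) in this assay, so this ring on the chain carbon brings the series a measured value at this position, although the floor of the step alone does not establish a change beyond the scatter. The ring on the chain does not reach the level of the amines joined to the aromatic carbon through a ring nitrogen, with a 3.0-fold higher number from compound 1 to compound 4 (0.48 log units; beyond the scatter) and a 3.1-fold higher number from compound 2 to compound 4 (0.49 log units; beyond the scatter).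

On these data alone, what a piperidin-4-yl or a dimethylamino group would give on the same saturated chain carbon remains open. As far as these compounds go, the outcome for the opposite configuration at the defined stereocentre of pyrrolidin-3-yl is also open.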